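A few compounds are considered here, and "the series" means these few. Any claim that something is new, unique, unknown or untested is made for them only; others in the source may bear on it.

Measured so far:
compound 1, `COc1ccc2[nH]c(C(=O)N3CC(=O)N(Cc4ccccc4)[C@@H](CN4CCC5(CC4)CC5)C3)cc2c1`: 28200 nM
compound 2, `COc1ccc2[nH]c(C(=O)N3CC(=O)N(Cc4ccccc4)[C@@H](N4CCc5ccccc54)C3)cc2c1`: 7000 nM

Compound 1 and compound 2 share a core and differ in one place. Within the data shown here, in a physicochemical assay for solubility, read by spectrophotometry, in phosphate buffer, with a stated time of 2 h, at pH 7.4 (a lower number here means a less soluble compound, a higher number a more soluble compound), compound 1 gives 28200 nM, and compound 2 gives 7000 nM, the lower of the two numbers; the only measured step, a 4.0-fold lower number from compound 1 to compound 2 (0.61 log units; beyond the scatter), is the whole of what is known here.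

Compound 3, `COc1ccc2[nH]c(C(=O)N3CC(=O)N(Cc4ccccc4)[C@@H](COc4ccc(F)cc4)C3)cc2c1`, is the next step from compound 2: (4-fluorophenoxy)methyl in place of 2,3-dihydro-1H-indol-1-yl on a saturated ring carbon. Among the measured compounds shown here, no measured pair shows this change. For the measured compounds named here, the one step on record, from compound 1 to compound 2, replaced a different group at the same saturated ring carbon and moved the number down by a modest amount, so it bears on the present change only loosely and gives no direction for a (4-fluorophenoxy)methyl group.

With nothing closer to go on, compound 3 is expected to stay near compound 2, and the step of a 1.2-fold lower number from compound 2 to compound 3 (0.07 log units; within the scatter) is estimated to lie within the scatter. The estimate for compound 3 in this assay is 6000 nM, with a range from 2000 nM to 20000 nM.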

Compound 3, solubility: 17500 nM
Beside the measured number, compound 3's estimate is 2.9-fold (0.46 log units) below it; the measured number falls inside the stated range.
By their numbers in this assay, from the lowest: compound 2; then compounds 3 and 1 (each within the scatter of the next).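

In this assay, the step of a 2.5-fold higher number from compound 2 to compound 3 (0.40 log units; beyond the scatter) shows that this saturated ring carbon can tell apart two groups that match in the heavy atoms, hydrogen-bond donors and acceptors counted for them and in having no net charge, so those counts alone do not set the number here. The step of a 1.6-fold lower number from compound 1 to compound 3 (0.21 log units; within the scatter) stays within the scatter even though the two groups on the saturated chain carbon differ in their rings, and among these three compounds, the two with a chain carbon bound to the saturated ring carbon read alike, while compound 2, whose ring nitrogen group sits directly on that ring carbon, stands apart. Nothing on record explains either result.

With three compounds, the effect of the chain carbon cannot be separated from that of the groups it carries, since 2,3-dihydro-1H-indol-1-yl appears only directly on the ring carbon. A 2,3-dihydro-1H-indol-1-ylmethyl group would isolate that link, and a carboxylic acid or a morpholine on the same chain carbon would show how far the similarity of compound 1 and compound 3 extends.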